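The compounds below may be only part of what the source reports. "The series", "measured", "known", "first", "only" and "open" are said of these compounds alone.

Measured compounds:
compound 1 `Cc1cc(-c2ccccc2)n(/C(N)=N/S(=O)(=O)c2cc(C)c(Cl)cc2SCc2ccccc2C)n1` — 42000 nM
compound 2 `Cc1cc(-c2ccccc2)n(/C(N)=N/S(=O)(=O)c2cc(C)c(Cl)cc2SCc2ccc(C(F)(F)F)cc2)n1` — 7000 nM
compound 3 `Cc1cc(-c2ccccc2)n(/C(N)=N/S(=O)(=O)c2cc(C)c(Cl)cc2SCc2cccc3ccccc23)n1` — 7000 nM

In a functional assay on HCT-116 cells (Homo sapiens) for cytotoxicity, read by MTT assay, with a stated time of 72 h (on this read-out lower numbers stand for stronger inhibition and higher numbers for weaker inhibition), compound 3 stands level with compound 2 and, together with it, gives the lowest of the three numbers; compound 1 gives the highest, a 6.0-fold lower number from compound 1 to compound 3 (0.78 log units; beyond the scatter). Compound 4 `Cc1cc(-c2ccccc2)n(/C(N)=N/S(=O)(=O)c2cc(C)c(Cl)cc2SCc2ccccc2Cl)n1` is a new variant: 2-chlorophenyl in place of naphthalen-1-yl on a saturated chain carbon bound to a sulfur. The step that bears most on this change is a 6.0-fold lower number from compound 1 to compound 3 (0.78 log units; beyond the scatter), since compound 1 also carries a small single ring with one group on it at this position, as compound 4 does. Reversing that step suggests the number for compound 4 should rise again, though the step from compound 2 to compound 3 shows that different groups here can also give equal numbers. Compound 4 is therefore expected at 25000 nM, with a range of 8000 nM to 60000 nM, which means an estimated step of a 3.6-fold higher number from compound 3 to compound 4 (0.55 log units; beyond the scatter).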

Compound 4, half-maximal inhibitory concentration: 170000 nM
Estimate against measurement, compound 4: 6.8-fold (0.83 log units) below, outside the stated range (above it).
By their numbers in this assay, from the lowest: compounds 2 and 3 (each within the scatter of the next); then compound 1; then compound 4.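

In this assay, going by these compounds alone, the group on a saturated chain carbon bound to a sulfur can shift the number much further than the earlier compounds showed: 2-chlorophenyl gives a large rise against naphthalen-1-yl (a 24-fold higher number from compound 3 to compound 4 (1.39 log units; beyond the scatter)) and against 4-(trifluoromethyl)phenyl (a 24-fold higher number from compound 2 to compound 4 (1.39 log units; beyond the scatter)). Even the small change of chloro in place of methyl on an aromatic carbon matters (a 4.0-fold higher number from compound 1 to compound 4 (0.61 log units; beyond the scatter)), so these two similar single rings do not behave alike. Nothing available explains these steps. Still open, from the compounds shown here alone, is how an amine or a carboxylic acid on this ring would compare, and whether a longer chain to the ring would change the number.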